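The source may hold more compounds than are shown below. What is called first, only, known or untested is meant among the compounds shown, and "the series" means these compounds.

Three close relatives of the unmeasured compound 4 have been tested in a functional assay on L1210 cells (Mus musculus) for cytotoxicity; on this read-out lower numbers stand for stronger inhibition and higher numbers for weaker inhibition. Compound 1 `CCCCCCCCc1cn([C@@H]2O[C@@H]3COP(=O)(O)O[C@H]3[C@H]2O)c(=O)nc1N` gives only a limit of the assay, > 200 ug/mL. Compound 2 `Cc1cn([C@@H]2O[C@@H]3COP(=O)(O)O[C@H]3[C@H]2O)c(=O)nc1N` likewise gives only a limit, > 200 ug/mL. Compound 3 `CCCc1cn([C@@H]2O[C@@H]3CO[PH](O)(O)O[C@H]3[C@H]2O)c(=O)nc1N` also gives only a limit, > 200 ug/mL. The step that the two limits leave unreadable from compound 1 to compound 2 cannot be read, as two limits hide its size. Compound 4 `CCCCc1cn([C@@H]2O[C@@H]3COP(=O)(O)O[C@H]3[C@H]2O)c(=O)nc1N` differs from compound 2 by propyl in place of hydrogen on a saturated chain carbon bound to an aromatic carbon. For the measured compounds named here, no measured step offers a readable size because the limit of > 200 ug/mL in this assay, at which 3 of the 3 values shown sit, holds every value shown, so no step beyond the scatter is expected in this assay. Compound 4 is therefore expected to stay near 200 ug/mL, between 100 ug/mL and 500 ug/mL. That expectation corresponds to an estimated step of a number no higher from compound 2 to compound 4 (the limit leaves the size open).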

Compound 4, concentration for 50% inhibition: > 200 ug/mL
Compound 4 was reported as a limit (the forecaster's own chance of this, stated with the estimate: 85%); the middle value sits exactly at the limit.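

For the compounds shown here, compound 1, compound 2 and compound 4 each give only a limit in this assay, and no step between them can be read. The compounds shown leave open whether the length of the chain affects inhibition at all.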